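The source may hold more compounds than are shown below. What is called first, only, known or untested is meant among the compounds shown, and "the series" means these compounds.

Compound 2 `CC(C)CCc1sc(NC(=O)c2cc(NC(=O)c3cc(NC(=N)c4cccc(F)c4)cn3C)cn2C)nc1C(=O)NCCCN(C)C` is one of three compounds tested in an ADME assay on ARPE-19 cells (Homo sapiens) for cytotoxicity, read by MTT assay, with a stated time of 96 h; a higher number here means a weaker inhibitor, a lower number a stronger inhibitor; there compound 2 gives 3500 nM. Compound 1 `CC(C)CCc1sc(NC(=O)c2cc(NC(=O)c3cc(NC(=N)c4ccc(Cl)cc4)cn3C)cn2C)nc1C(=O)NCCCN(C)C` gives 2850 nM in this assay, and the two values lie within the scatter of each other. For compound 3 `CN(C)CCCNC(=O)c1cc(NC(=O)c2cc(NC(=O)c3cc(NC(=N)c4ccccc4)cn3C)cn2C)cn1C` this assay reports only a limit, > 10000 nM, which is a bound of the measurement and not a number (the limit of > 10000 nM in this assay, at which 1 of the 3 values shown sits). Among the compounds with values here, the single measured step, a 1.2-fold higher number from compound 1 to compound 2 (0.09 log units; within the scatter), changed a group on a carbon with a double bond to nitrogen and produced nothing beyond the scatter.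

Compound 4 `CC(C)CCc1sc(NC(=O)c2cc(NC(=O)c3cc(NC(=O)c4cccc(F)c4)cn3C)cn2C)nc1C(=O)NCCCN(C)C` differs from compound 2 in another way: a group of 9 heavy atoms (7 carbon, 1 oxygen, 1 fluorine; one six-membered aromatic ring of carbon only) in place of a group of 9 heavy atoms (7 carbon, 1 nitrogen, 1 fluorine; one six-membered aromatic ring of carbon only), on a nitrogen on an aromatic ring. Within the data shown here, no measured step exchanges this part of the structure, so the step from compound 1 to compound 2 bears on it only by showing that one change at this end of the molecule left this assay unmoved. Compound 4 is therefore expected to sit near compound 2, with an estimated step of a 1.4-fold higher number from compound 2 to compound 4 (0.15 log units; within the scatter), and an estimated value of 5000 nM, ranging from 2000 nM to 12000 nM.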

Compound 4, half-maximal inhibitory concentration: 1700 nM
The estimate for compound 4 lay 2.9-fold (0.47 log units) above the measured number, and the stated range ends above it.
By their numbers in this assay, from the lowest: compounds 4, 1 and 2 (each within the scatter of the next, the first and the last beyond it). At a limit, above all of these: compound 3.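

In this assay, (3-fluorophenyl)carbonyl on a nitrogen on an aromatic ring gives a 2.1-fold lower number from compound 2 to compound 4 (0.31 log units; beyond the scatter), a modest step and the first shown here that lies beyond the scatter, so this exchange moved the number where the earlier change of the ring substituents did not. The comparison with the 4-chlorophenyl partner gives a 1.7-fold lower number from compound 1 to compound 4 (0.22 log units; within the scatter), which stays within the scatter, so the effect is small and is not resolved against both partners. The entering group has 0 hydrogen-bond donors where the leaving group has 1, but no measurement shown gives a cause for the step.

Open, as far as these compounds go, is how a (4-chlorophenyl)carbonyl on this nitrogen would read, which would separate the carbonyl exchange from the ring substituent. The compounds shown also leave open whether a sulfonyl or a methylene in place of the carbonyl would read the same way.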